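This account rests on a few compounds, and the source may have more. Where it says the series, first, only, none or still open, it means among the compounds named here.

Measured compounds and their values in a functional assay on HepG2 cells (Homo sapiens) for cytotoxicity, read by MTT assay; on this read-out lower numbers stand for stronger inhibition and higher numbers for weaker inhibition:
Compound 1, `CCOC(=O)c1c(NCc2nc3ccccc3[nH]2)sc2c1CCCCC2`, gives 43000 nM.
Compound 2, `CC1=NN(Cc2nc3ccccc3[nH]2)C(=O)C1`, gives 54000 nM.
Compound 3, `Cc1c(NCc2nc3cc([N+](=O)[O-])ccc3[nH]2)c(=O)n(-c2ccccc2)n1C`, gives 93000 nM.

All three numbers sit within the usual scatter of one another, so no order among them can be read. Compound 2 stands second highest of the three; its nearest neighbour is compound 1 and its furthest is compound 3, both within the scatter.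

Compound 4, `CC1=NN(Cc2nc3cc([N+](=O)[O-])ccc3[nH]2)C(=O)C1`, has not yet been measured. Its change from compound 2 is nitro in place of hydrogen on an aromatic carbon. Going by the values given here, no comparable step between measured compounds exists here, so the expectation for this assay is a step of no more than the scatter, with no direction claimed. Compound 4 is therefore estimated at 60000 nM, within 25000 nM to 150000 nM, meaning an expected step of a 1.1-fold higher number from compound 2 to compound 4 (0.05 log units; within the scatter).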

Compound 4, half-maximal inhibitory concentration: 265000 nM
For compound 4 the middle estimate is 4.4-fold (0.65 log units) below the measured one, and the stated range ends below it.
By their numbers in this assay, from the lowest: compounds 1, 2 and 3 (each within the scatter of the next, the first and the last beyond it); then compound 4.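

In this assay, going by these compounds alone, nitro in place of hydrogen on an aromatic carbon gives a modest step beyond the scatter (a 4.9-fold higher number from compound 2 to compound 4 (0.69 log units; beyond the scatter)), the first such step between compounds that differ in one place. This position on the shared core therefore responds to substitution, and here the change goes towards weaker inhibition. Nothing available accounts for the step.

Going by these compounds, whether an amine or a methoxy group at this place would shift the number in the same way remains open. Compound 3 also carries nitro, but with no partner lacking it, the change cannot be read on that core.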